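A few compounds are considered here, and "the series" means these few. Any claim that something is new, unique, unknown or untested is made for them only; others in the source may bear on it.

Compound 1 `O=C1C=C(NCc2ccccc2)C(=O)c2c1nc1n2[C@H]2OC[C@@H](O)[C@H]2OC1` gives > 8000 nM in a functional assay on MCF7 cells (Homo sapiens) for inhibition, read by sulforhodamine B assay; a lower number here means a stronger inhibitor, a higher number a weaker inhibitor.
Compound 2 `O=C1C(Nc2ccccc2F)=CC(=O)c2c1nc1n2[C@H]2OC[C@@H](O)[C@H]2OC1` gives > 4000 nM in this assay.
Compound 3 `COc1ccc(NC2=CC(=O)c3nc4n(c3C2=O)[C@H]2OC[C@@H](O)[C@H]2OC4)cc1` gives 5420 nM in this assay.

The value of compound 2 is a limit of this assay and not a number (the limit of > 4000 nM in this assay, at which 1 of the 3 values shown sits). The value of compound 1 is likewise a limit (the limit of > 8000 nM in this assay, at which 1 of the 3 values shown sits). Compound 3 alone is given as a number, and it sits at the weak end. Compound 4 `COc1cccc(NC2=CC(=O)c3c(nc4n3[C@H]3OC[C@@H](O)[C@H]3OC4)C2=O)c1` differs from compound 2 by 3-methoxyphenyl in place of 2-fluorophenyl on an amine nitrogen. Among the measured compounds shown here, the only measured step, an at least 1.4-fold lower number from compound 1 to compound 3 (0.16 log units; that floor lies within the scatter), starts from a different compound and exchanges a benzyl rather than a 2-fluorophenyl, so it bears on compound 4 only loosely; it shows a methoxyphenyl on the amine nitrogen reaching a number where compound 1 does not. For the measured compounds named here, no step connects compound 2 and compound 3, which carry different groups on the amine nitrogen. Compound 4 is therefore expected to land close to compound 3, and the step that the limit leaves unreadable from compound 2 to compound 4 is expected to be small or none beyond the scatter, its direction left open by the limit on compound 2. For compound 4 the estimate is 6000 nM, with a range from 2500 nM to 15000 nM, and a fair chance that only a limit is reported.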

Compound 4, half-maximal inhibitory concentration: 3830 nM
Compound 4: middle estimate off by 1.6-fold (0.19 log units), on the high side, within the range that was stated.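

In this assay, 3-methoxyphenyl in place of 2-fluorophenyl on the amine nitrogen gives an at least 1.0-fold lower number from compound 2 to compound 4 (0.01 log units; that floor lies within the scatter). The true size of this step stays open, since the value of compound 2 is a limit of the assay and not a number: the limit of > 4000 nM in this assay, at which 1 of the 4 values shown sits.
What compound 4 adds is a second aryl group on this nitrogen that yields a number, as the 4-methoxyphenyl of compound 3 does, so both methoxyphenyl compounds shown can be read as numbers.

The compounds shown leave open whether any group on this amine nitrogen can bring the number down beyond the scatter. Going by these compounds, how an unsubstituted phenyl, a pyridine or a longer chain ending in an amine would read at this place also remains open.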